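A few compounds are considered here, and "the series" means these few. Any claim that something is new, unique, unknown or untested is made for them only; others in the source may bear on it.

Measured in a functional assay on HL-60 cells (Homo sapiens) for inhibition, read by MTT assay, with a stated time of 72 h; on this read-out higher numbers stand for weaker inhibition and lower numbers for stronger inhibition:
Compound 1 `Cc1nc(-c2cccc(F)c2)c(C(=O)N2CCN(c3cccc(Cl)c3)CC2)o1`: 33.7 nM
Compound 2 `Cc1nc(-c2ccccc2Cl)c(C(=O)N2CCN(c3cccc(Cl)c3)CC2)o1`: 132 nM

Compound 2 has the higher number of the two, and the gap is a 3.9-fold higher number from compound 1 to compound 2 (0.59 log units; beyond the scatter). Compound 3 `COc1ccc(-c2nc(C)oc2C(=O)N2CCN(c3cccc(Cl)c3)CC2)cc1O` has not yet been measured. It carries 3-hydroxy-4-methoxyphenyl in place of 2-chlorophenyl on an aromatic carbon of the shared core: 3-hydroxy-4-methoxyphenyl in place of 2-chlorophenyl on an aromatic carbon. Within the data shown here, the one measured step at this place is the modest one above, and neither measured compound carries a hydroxy or methoxy group, so the evidence is thin. Compound 3 gives up the 2-chlorophenyl of compound 2, and the lower value belongs to compound 1 with its 3-fluorophenyl, at 33.7 nM. A step of similar modest size toward a lower number is therefore expected in this assay. The estimated step is a 3.8-fold lower number from compound 2 to compound 3 (0.58 log units; beyond the scatter). For compound 3 the estimated value is 35 nM, within an expected range of 7 nM to 170 nM.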

Compound 3, half-maximal inhibitory concentration: "not active" (no number reported)
No number was reported for compound 3; there is nothing to compare the estimate with.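

Among these compounds, compound 3 is reported as "not active" in this assay without a number, and no step from compound 2 to compound 3 can be read. Nothing shown here accounts for this result. The compounds shown leave open how much weaker, if at all, 3-hydroxy-4-methoxyphenyl is than 2-chlorophenyl at this place.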